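Swapping the amide heteroaryl on an ethynyl-bearing core

The source may hold more compounds than are shown below. What is called first, only, known or untested is meant among the compounds shown, and "the series" means these compounds.

Measured compounds in a functional assay on BMDM cells (Mus musculus, strain C57BL/6) for inhibition, with a stated time of 2 days; a lower number here means a stronger inhibitor, a higher number a weaker inhibitor:
compound 1, `Cc1cc(NC(=O)Cn2cc(-c3ccc([N+](=O)[O-])cc3)nn2)no1`, 1220 nM
compound 2, `COC(=O)c1ccc(-c2cn(CC(=O)Nc3cc(C)on3)nn2)cc1`, only a limit, > 30000 nM
compound 3, `C#Cc1ccc(-c2cn(CC(=O)Nc3nccs3)nn2)cc1`, only a limit, > 30000 nM

Compound 3 therefore stands at the limit of this assay rather than at a number, together with one other of the three values (the limit of > 30000 nM in this assay, at which 2 of the 3 values shown sit). For the measured compounds named here, the single measured step, an at least 24-fold higher number from compound 1 to compound 2 (1.39 log units; beyond the scatter), concerns a group on an aromatic carbon of the shared core, not the substituent on the amide-type nitrogen, so it does not speak to the change considered here.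

Compound 4, `C#Cc1ccc(-c2cn(CC(=O)Nc3cc(C)on3)nn2)cc1`, differs from compound 3 by 5-methyl-1,2-oxazol-3-yl in place of 1,3-thiazol-2-yl on an amide-type nitrogen. Compound 1 and compound 2 both carry the entering 5-methyl-1,2-oxazol-3-yl group, and their values run from a number to a limit, so that group alone does not fix the outcome. Going by the values given here, no measured step bears on this change, and no step beyond the scatter is expected from it; compound 3 at the limit leaves the direction open. Compound 4 is accordingly expected to remain weak, at about 20000 nM, in the range 5000 nM to 60000 nM, which amounts to an expected step of an at least 1.5-fold lower number from compound 3 to compound 4 (0.17 log units; that floor lies within the scatter).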

Compound 4, half-maximal inhibitory concentration: > 30000 nM
Compound 4: no number, only a limit; the forecaster's own chance of this, stated with the estimate: 55%; middle value at least 1.5-fold (0.17 log units) away from the limit.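

With the 5-methyl-1,2-oxazol-3-yl group held fixed on the amide-type nitrogen, ethynyl in place of nitro on an aromatic carbon gives an at least 24-fold higher number from compound 1 to compound 4 (1.39 log units; beyond the scatter). Methoxycarbonyl is thus no longer the only replacement for nitro shown to end at a limit in this assay. Replacing 1,3-thiazol-2-yl with 5-methyl-1,2-oxazol-3-yl also gives no number on the ethynyl-bearing core, and the steps to compound 4 from compound 2 and from compound 3 cannot be read, with both ends of each at a limit: the limit of > 30000 nM in this assay, at which 3 of the 4 values shown sit.

The compounds shown leave open how the two amide groups compare, since neither gives a number on this core. They also leave open whether 1,3-thiazol-2-yl would give a number alongside nitro, and whether an amine or a carboxylic acid in place of nitro would do so.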